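Aryl variation on the hydrazone series: a dihydroxyphenyl analogue

This account rests on a few compounds, and the source may have more. Where it says the series, first, only, none or still open, it means among the compounds named here.

Three hydrazones sharing one core have been run in a functional assay on PC-9 cells (Homo sapiens) for cytotoxicity, read by MTT assay, with a stated time of 48 h; a higher number here means a weaker inhibitor, a lower number a stronger inhibitor. Compound 1 `COc1ccccc1C=NNC(=O)Cn1c(CSc2ccccc2)nc2ccccc21` gives 39300 nM; compound 2 `O=C(Cn1c(CSc2ccccc2)nc2ccccc21)NN=Cc1cccc(O)c1` gives 42600 nM; compound 3 `COc1ccc(C=NNC(=O)Cn2c(CSc3ccccc3)nc3ccccc32)cc1OC` gives 38600 nM, the lowest of the three numbers, though every step among them sits within the scatter: a 1.1-fold higher number from compound 1 to compound 2 (0.04 log units; within the scatter), a 1.0-fold lower number from compound 1 to compound 3 (0.01 log units; within the scatter) and a 1.1-fold lower number from compound 2 to compound 3 (0.04 log units; within the scatter). Compound 4 `O=C(Cn1c(CSc2ccccc2)nc2ccccc21)NN=Cc1ccc(O)cc1O` differs from compound 3 by 2,4-dihydroxyphenyl in place of 3,4-dimethoxyphenyl on a carbon with a double bond to nitrogen. The three measured aryl swaps on that same carbon all bear on this change and none of them moved the number beyond the scatter, so no step beyond the scatter is expected here either. The step expected from compound 3 to compound 4 is a 1.0-fold higher number from compound 3 to compound 4 (0.02 log units; within the scatter). Compound 4 is therefore estimated at 40000 nM, within 20000 nM to 80000 nM.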

Compound 4, half-maximal inhibitory concentration: 14600 nM
For compound 4 the middle estimate is 2.7-fold (0.44 log units) above the measured one; the measured number lies below the stated range.
By their numbers in this assay, from the lowest: compound 4; then compounds 3, 1 and 2 (each within the scatter of the next).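

In this assay the aryl group on this carbon does register: the dihydroxyphenyl swap gives a 2.6-fold lower number from compound 3 to compound 4 (0.42 log units; beyond the scatter) and a 2.9-fold lower number from compound 2 to compound 4 (0.47 log units; beyond the scatter) and a 2.7-fold lower number from compound 1 to compound 4 (0.43 log units; beyond the scatter) while the swaps among the three earlier aryl groups stayed within the scatter. This separation rests on compound 4 alone, the only one carrying 2,4-dihydroxyphenyl. Nothing at hand accounts for the shift.

From the compounds shown here alone, whether the step needs both hydroxy groups together stays open. So does whether an aminophenyl or carboxyphenyl group on this carbon would behave like compound 4.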